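Removing one chloro from a dichlorophenyl anilinoenone thioglycoside

The compounds below may be only part of what the source reports. "The series", "measured", "known", "first", "only" and "open" are said of these compounds alone.

The measured compounds and their values:
compound 1 `CC1(C)CC(=O)C=C(Nc2ccc(Cl)cc2Cl)C1` — "not determined" (no result reported)
compound 2 `CC(=O)OC[C@H]1O[C@@H](SC(=S)C2=C(Nc3ccc(Cl)cc3Cl)CC(C)(C)CC2=O)[C@H](OC(C)=O)[C@@H](OC(C)=O)[C@@H]1OC(C)=O` — "not determined" (no result reported)
compound 3 `CC(=O)OC[C@H]1O[C@@H](SC(=S)C2=C(Nc3ccc(Cl)cc3Cl)CC(C)(C)CC2=O)[C@H](OC(C)=O)[C@@H](OC(C)=O)[C@H]1OC(C)=O` — > 20 ug/mL

Three compounds share a core built on a dimethylcyclohexenone bearing a (2,4-dichlorophenyl)amino group. In an ADME assay on CC-1 cells (Rattus norvegicus, strain Wistar) for cytotoxicity, read by MTT assay, with a stated time of 48 h (a lower number here means a stronger inhibitor, a higher number a weaker inhibitor), compound 1 gives "not determined" (no result reported), and in this assay compound 2 gives "not determined" (no result reported), so no number exists for compound 2 and it cannot be placed on a scale. Compound 3 stands alone with a reported entry: in this assay compound 3 gives > 20 ug/mL, which is a limit of the assay and not a number.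

The piece follows the step from compound 2 to compound 4 `CC(=O)OC[C@H]1O[C@@H](SC(=S)C2=C(Nc3ccc(Cl)cc3)CC(C)(C)CC2=O)[C@H](OC(C)=O)[C@@H](OC(C)=O)[C@@H]1OC(C)=O`. The change is hydrogen in place of chloro on an aromatic carbon. Among the compounds with values here, no measured step exists for this pair, so no size can be read from the data. Because of the fact that compounds 2 and 3 differ only in the configuration as drawn the entry for compound 3 is the closest guide to where compound 2 would sit, and because of the limit of > 20 ug/mL in this assay, at which 1 of the 3 values shown sits, that guide is itself only a limit. A step beyond the usual scatter in this assay is not expected in either direction; the result is expected to end at the same limit.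

Compound 4 is therefore expected to give about 30 ug/mL in this assay, estimated between 12 ug/mL and 80 ug/mL.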

Compound 4, half-maximal inhibitory concentration: > 20 ug/mL
Compound 4: a limit, no number; the forecaster's own chance of this, stated with the estimate: 70%; the middle value is on the limit's open side.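

In this assay compound 4 gives > 20 ug/mL, which is a limit of the assay and not a number. Compound 2 has no number either, so no step can be read between compound 2 and compound 4. The compounds shown leave open whether going from 2,4-dichlorophenyl to 4-chlorophenyl shifts the result in this assay at all, and by how much.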